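Ethyl in place of methyl on the cyanoguanidine side chain

The source may hold more compounds than are shown below. What is called first, only, known or untested is meant among the compounds shown, and "the series" means these compounds.

Measured so far:
compound 1 `N#CNC(=N)NCCCCCn1nc(-c2ccccc2)ccc1=O` — 31%
compound 2 `CC/N=C(\S)NCCCCCn1nc(-c2ccccc2)ccc1=O` — 66.4%
compound 3 `C/N=C(/NC#N)NCCCCCn1nc(-c2ccccc2)ccc1=O` — 47.6%

In a functional assay on the whole organism with Rattus norvegicus as the target, at a dose of 100 mg/kg (on this read-out higher numbers stand for more inhibition at the one dose given (going by the name of the read-out) and lower numbers for less inhibition), compound 3 stands second highest of the three: compound 1 sits lower by a number 16.6 percentage points higher from compound 1 to compound 3 (beyond the scatter) and compound 2 higher by a number 18.8 percentage points lower from compound 2 to compound 3 (beyond the scatter), both beyond the scatter. Compound 4 `CC/N=C(/NC#N)NCCCCCn1nc(-c2ccccc2)ccc1=O` differs from compound 3 by methyl in place of hydrogen on a saturated chain carbon bound to a double-bonded nitrogen, so the change, read one bond further out, is methyl to ethyl. Going by the values given here, no measured step covers exactly this move. The nearest guide is the step from the unsubstituted chain to the methylated one, a number 16.6 percentage points higher from compound 1 to compound 3 (beyond the scatter), a modest gain; compound 2, which carries an ethyl on a different group, gives 66.4%. Lengthening the chain further is therefore expected to keep the level of compound 3 or raise it slightly, an expected step of a number 7.4 percentage points higher from compound 3 to compound 4 (within the scatter). Compound 4 is estimated at 55%, within a range of 35% to 75%.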

Compound 4, a percentage reported as inhibition, in the whole organism at one dose (the size of the read-out at that dose, not a potency): 48.2%
Estimate against measurement, compound 4: 6.8 percentage points above; the measured number falls inside the stated range.
By their numbers in this assay, from the lowest: compound 1; then compounds 3 and 4 (each within the scatter of the next); then compound 2.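

In this assay, the change from methyl to ethyl on the saturated chain carbon bound to a double-bonded nitrogen gives a number 0.6 percentage points higher from compound 3 to compound 4 (within the scatter), so at this position the two alkyl groups cannot be told apart. Compound 4 keeps a clear margin over the compound without an alkyl group, with a number 17.2 percentage points higher from compound 1 to compound 4 (beyond the scatter), yet it stays apart from the sulfur-bearing compound that also carries an ethyl, with a number 18.2 percentage points lower from compound 2 to compound 4 (beyond the scatter), which shows that an ethyl group alone does not bring the cyanoguanidine to that level. Nothing available here bears on why the read-out behaves this way.

On these data alone, whether a propyl group, a longer chain or a cyclopropyl ring at this place would move the read-out remains open. So does how the sulfur-bearing series would respond to methyl in place of ethyl.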